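This account rests on a few compounds, and the source may have more. Where it says the series, first, only, none or still open, it means among the compounds named here.

Among the measured compounds shown here, in a functional assay on LNCaP cells (Homo sapiens) for cytotoxicity (on this read-out higher numbers stand for weaker inhibition and lower numbers for stronger inhibition), compound 2 (`CNC(=O)Nc1ccc(-c2nc(N3CC4CCC(C3)O4)c3cnn([C@H]4CC[C@H](OC)CC4)c3n2)cc1`) gives 2 nM, the lower of the two numbers so far, while compound 1 (`CNC(=O)Nc1ccc(-c2nc(N3CC4CCC(C3)O4)c3cnn(CCO)c3n2)cc1`) gives 650 nM. Compound 3 (`CCn1ncc2c(N3CC4CCC(C3)O4)nc(-c3ccc(NC(=O)NC)cc3)nc21`) carries ethyl in place of 4-methoxycyclohexyl on an aromatic nitrogen. For the measured compounds named here, the only measured step bearing on this change, a 330-fold lower number from compound 1 to compound 2 (2.51 log units; beyond the scatter), is large and concerns the same aromatic nitrogen. Ethyl resembles the 2-hydroxyethyl of compound 1 more than the group it replaces, so a large rise is expected in this assay. The estimated step is a 40-fold higher number from compound 2 to compound 3 (1.60 log units; beyond the scatter). For compound 3 the expected value is 80 nM, with an estimated range of 10 nM to 500 nM.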

Compound 3, half-maximal inhibitory concentration: 70 nM
Beside the measured number, compound 3's estimate is 1.1-fold (0.06 log units) above it; measured number inside the range.
By their numbers in this assay, from the lowest: compound 2; then compound 3; then compound 1.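

Taking the 4-methoxycyclohexyl group away for ethyl on the aromatic nitrogen gives a 35-fold higher number from compound 2 to compound 3 (1.54 log units; beyond the scatter) in this assay, so the larger share of the earlier gap goes with that group. Hydrogen in place of hydroxy on the chain alone gives a 9.3-fold lower number from compound 1 to compound 3 (0.97 log units; beyond the scatter), a smaller but real share. Nothing shown explains either step.

On these data alone, whether the gain lies in the cyclohexyl ring itself or in its methoxy remains open. A plain cyclohexyl, a 4-hydroxycyclohexyl or a longer chain such as butyl on this nitrogen would separate these.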